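The source may report more compounds than this note shows. Statements on the series, on what has been measured and on what is new or still open speak of the compounds shown alone.

Measured so far:
compound 1, `CCN(Cc1ccccc1)C(=O)c1nc(-c2ccc(F)cc2)c2ccccc2n1`, in an assay on cell membranes from kidney for displacement of a labelled ligand from Translocator protein (Rattus norvegicus) (a higher number here means a weaker inhibitor, a lower number a stronger inhibitor), gives 1.68 nM;
compound 2, `CCN(Cc1ccc(C)cc1)C(=O)c1nc(-c2ccccc2)c2ccccc2n1`, in this assay gives 2.57 nM.

Among the measured compounds shown here, compound 2 holds the higher of the two numbers so far, but its gap to compound 1 is within the scatter, so the two are not separated. Compound 3, `CCOC(=O)c1ccc(CN(CC)C(=O)c2nc(-c3ccccc3)c3ccccc3n2)cc1`, is not yet measured in this assay. Against compound 2 the change is ethoxycarbonyl in place of methyl on an aromatic carbon. For the measured compounds named here, no step between measured compounds is known, so the expectation rests on the change alone: a small loss of potency is expected, a 1.8-fold higher number from compound 2 to compound 3 (0.24 log units; within the scatter), not far beyond the scatter. For compound 3 in this assay the estimate is 4.5 nM, with a range from 1.5 nM to 14 nM.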

Compound 3, inhibition constant: 3.65 nM
Compound 3: the middle estimate sits 1.2-fold (0.09 log units) above what was measured; measured number inside the range.
By their numbers in this assay, from the lowest: compounds 1, 2 and 3 (each within the scatter of the next, the first and the last beyond it).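

Working at the aromatic carbon para to a large group, ethoxycarbonyl in place of methyl gives a 1.4-fold higher number from compound 2 to compound 3 (0.15 log units; within the scatter) in this assay and does not separate the two compounds. This position therefore carries a group of 5 heavy atoms, with 2 hydrogen-bond acceptors, as well as methyl with 1 heavy atom and none. Nothing measured here bears on the reason for this result.

As far as these compounds go, a carboxylic acid, an amine or a longer ester chain at this position remains open. From the compounds shown here alone, whether the same change reads the same way on the core of compound 1 also remains open.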